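The source may hold more compounds than are shown below. What is called first, only, known or untested is meant among the compounds shown, and "the series" means these compounds.

Compound 1 `CCOC(=O)C1=C(Nc2ccc(OC)cc2)S/C(=C\c2ccc[nH]2)C1=O` in a functional assay on MCF7 cells (Homo sapiens) for inhibition, read by MTT assay, with a stated time of 72 h, tested at 10 uM (a lower number here means less inhibition, a higher number more inhibition at the concentration tested (going by the name of the read-out)), gives only a limit, < 10%. That value sits at the limit of < 10% in this assay, at which 1 of the 2 values shown sits. A second compound, compound 2 `CCOC(=O)C1=C(Nc2ccccc2Br)S/C(=C\c2ccc[nH]2)C1=O`, in this assay gives 29.4%. The step of a number at least 19.4 percentage points higher from compound 1 to compound 2 (beyond the scatter) exchanges the whole substituted phenyl on the amine nitrogen, and it is known only as a minimum. Compound 3 `CCOC(=O)C1=C(Nc2ccc(C(F)(F)F)cc2)S/C(=C\c2ccc[nH]2)C1=O` differs from compound 1 by trifluoromethyl in place of methoxy on an aromatic carbon. For the measured compounds named here, only the one measured step bears on this change, and it is a different change at a different place, so the guidance it gives is loose. Still, the one substitution seen on that aryl ring moved the read-out upward, and a modest rise in inhibition is expected here too, a number at least 12 percentage points higher from compound 1 to compound 3 (beyond the scatter). Compound 3 is therefore estimated at 22% in this assay, with an expected range from 5% to 42%.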

Compound 3, a percentage reported as inhibition, at one concentration (the size of the read-out at that concentration, not a potency): 19.1%
Estimate against measurement, compound 3: 2.9 percentage points above, and the stated range covers the measured number.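

Exchanging methoxy for trifluoromethyl on the aromatic carbon para to a large group gives, in this assay, a number at least 9.1 percentage points higher from compound 1 to compound 3 (that floor lies within the scatter). Unlike the exchange of the whole substituted phenyl, this change does not establish a rise on its own: its size is known only as a minimum, and that minimum does not clear the scatter. Compound 1 stands at a limit of the assay rather than at a number, and this limit sets the floor of the step: the limit of < 10% in this assay, at which 1 of the 3 values shown sits.

The compounds shown leave open how large the real gap between methoxy and trifluoromethyl is at this position, and whether there is one at all. They also leave open how an amine or a carboxylic acid on this same aromatic carbon would read in this assay.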